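Pyridin-2-yl Replaces the Difluorophenyl Ring

The compounds below may be only part of what the source reports. "The series", "measured", "known", "first", "only" and "open" are said of these compounds alone.

Compound 3 `N=C(NCCCc1c[nH]cn1)NC(=O)CC(c1ccccc1)c1ccc(F)c(F)c1` gives 81% in a functional assay on cardiac atrium for agonist activity at histamine H2 receptor (Cavia porcellus); on this read-out higher numbers stand for larger maximal responses and lower numbers for smaller maximal responses. Compound 2 `N=C(NCCCc1c[nH]cn1)NC(=O)CC(c1ccccc1)c1ccc(F)cc1` gives 95%, and the step of a number 14 percentage points lower from compound 2 to compound 3 (beyond the scatter) lies beyond the scatter, so compound 3 sits below compound 2. Compound 1 `N=C(NCCCc1c[nH]cn1)NC(=O)CC(c1ccccc1)c1ccccc1` gives 85%, and the step of a number 4 percentage points lower from compound 1 to compound 3 (within the scatter) stays within the scatter, so compound 3 and compound 1 cannot be told apart. Compound 4 `N=C(NCCCc1c[nH]cn1)NC(=O)CC(c1ccccc1)c1ccccn1` differs from compound 3 by pyridin-2-yl in place of 3,4-difluorophenyl on a saturated chain carbon bound to an aromatic carbon and a saturated chain carbon. The measured steps of a number 10 percentage points higher from compound 1 to compound 2 (within the scatter) and a number 14 percentage points lower from compound 2 to compound 3 (beyond the scatter) concern fluoro on the ring and were at most modest; nothing measured involves a pyridin-2-yl. On this basis the expected step is a number 4 percentage points higher from compound 3 to compound 4 (within the scatter), close to none beyond the scatter. Compound 4 is estimated at 85%, with a range from 65% to 100%.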

Compound 4, largest response reached (Emax), in percent of the reference or control that the assay uses: 97%
For compound 4 the middle estimate is 12 percentage points below the measured one; low and high end bracket the measured number.
By their numbers in this assay, from the lowest: compounds 3, 1, 2 and 4 (each within the scatter of the next, the first and the last beyond it).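

At this saturated chain carbon, a ring with a hetero atom holds the response in this assay, which the fluoro changes alone could not show: pyridin-2-yl gives a number 16 percentage points higher from compound 3 to compound 4 (beyond the scatter) and a number 12 percentage points higher from compound 1 to compound 4 (beyond the scatter), both modest. Against 4-fluorophenyl the change gives only a number 2 percentage points higher from compound 2 to compound 4 (within the scatter), so these two rings cannot be told apart here. No evidence at hand bears on this result.

Open, on these data alone, is whether pyridin-3-yl or pyridin-4-yl at the same carbon would match pyridin-2-yl, and how a pyrimidin-2-yl ring would compare.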